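The source may hold more compounds than are shown below. What is called first, only, known or untested is meant among the compounds shown, and "the series" means these compounds.

Measured in an ADME assay on HepG2 cells (Homo sapiens) for cytotoxicity, read by MTT assay, with a stated time of 48 h; a higher number here means a weaker inhibitor, a lower number a stronger inhibitor:

Compound 1 `O=S(=O)(c1ccc(-c2ccc3ncnc(Nc4ccc(O)c(Cl)c4)c3c2)cc1)N1CCOCC1`: > 15000 nM, a limit.
Compound 2 `O=S(=O)(c1ccc(-c2ccc3ncnc(Nc4ccc(OCc5ccccc5)c(Cl)c4)c3c2)cc1)N1CCOCC1`: > 15000 nM, a limit.
Compound 3 `O=S(=O)(c1ccc(-c2ccc3ncnc(Nc4ccc(OCc5cccc(F)c5F)c(Cl)c4)c3c2)cc1)N1CCOCC1`: > 15000 nM, a limit.

Compound 3 has no exact number, only this limit. It shares that position with the other two compounds, as the limit of > 15000 nM in this assay, at which 3 of the 3 values shown sit, shows.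

Compound 4 `COc1cccc(COc2ccc(Nc3ncnc4ccc(-c5ccc(S(=O)(=O)N6CCOCC6)cc5)cc34)cc2Cl)c1` differs from compound 3 in a single group: 3-methoxyphenyl in place of 2,3-difluorophenyl on a saturated chain carbon bound to an oxygen on an aromatic ring. Put simply, 3-methoxyphenyl stands in place of 2,3-difluorophenyl on a saturated chain carbon bound to an oxygen on an aromatic ring.

Going by the values given here, the closest precedent is a change at that same place, a step that the two limits leave unreadable from compound 2 to compound 3. Two further changes add a group to the oxygen, a step that the two limits leave unreadable from compound 1 to compound 2 and a step that the two limits leave unreadable from compound 1 to compound 3. None of these three gives a size to carry over to the new change, so the forecast rests on where the compounds stand, not on a measured step.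

Compound 3 is the direct reference, with its limit of > 15000 nM. Compound 4 is therefore expected to sit at or near the same limit in this assay, with no step beyond the scatter. The estimated change is a step that the limit leaves unreadable from compound 3 to compound 4, and neither direction is favoured. For compound 4 the expected value is 20000 nM, within an estimated range from 12000 nM to 45000 nM.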

Compound 4, half-maximal inhibitory concentration: > 15000 nM
Compound 4: only a limit was reported (the forecaster's own chance of this, stated with the estimate: 85%); the middle value lies beyond the limit too.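

No step among compound 1, compound 2, compound 3 and compound 4 can be read, because all four stand at one limit of the assay rather than at an exact number: the limit of > 15000 nM in this assay, at which 4 of the 4 values shown sit.

The compounds shown leave open whether any of the four differs from another in this assay, and at what concentration any of them would reach half-maximal inhibition.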